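A few compounds are considered here, and "the series" means these few. Any claim that something is new, unique, unknown or untested is made for them only; others in the source may bear on it.

Within the data shown here, compound 3 `C[S+]([O-])c1cccc(C#Cc2cc(Cl)ccc2OCC(=O)O)c1` gives 3.2 nM in an assay on CHO cells for displacement of a labelled ligand from prostaglandin D2 receptor 2 (Homo sapiens), read by scintillation counting (on this read-out higher numbers stand for weaker inhibition and lower numbers for stronger inhibition), the lowest of the three numbers measured so far. Its nearest neighbour is compound 1 `CN(C)C(=O)c1cccc(C#Cc2cc(Cl)ccc2OCC(=O)O)c1`, which in this assay gives 52 nM; the step of a 16-fold lower number from compound 1 to compound 3 (1.21 log units; beyond the scatter) is large and lies well beyond the scatter. Compound 2 `O=C(O)COc1ccc(Cl)cc1C#Cc1ccncc1` gives 601 nM in this assay and stands furthest from compound 3. Compound 4 `O=C(O)COc1ccc(Cl)cc1C#Cc1ccccc1` has not yet been measured. Compared with compound 3, the change is a hydrogen atom in place of a group of 3 heavy atoms (1 carbon, 1 oxygen, 1 sulfur; no ring), on an aromatic carbon, on a six-membered aromatic ring of carbon only, meta to a large group.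

Among the measured compounds shown here, no measured step removes this group altogether. For the measured compounds named here, the one step that touches the same place, a 16-fold lower number from compound 1 to compound 3 (1.21 log units; beyond the scatter), shows that exchanging one group for another there can move the number a long way, with the methylsulfinyl group of compound 3 giving the lower number. Taking the group away is therefore expected to raise the number, by an estimated step of a 25-fold higher number from compound 3 to compound 4 (1.40 log units; beyond the scatter). Compound 4 is expected to give about 80 nM in this assay, within a range of 15 nM to 400 nM.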

Compound 4, inhibition constant: 108 nM
Beside the measured number, compound 4's estimate is 1.4-fold (0.13 log units) below it; the range from low to high includes it.
By their numbers in this assay, from the lowest: compound 3; then compound 1; then compound 4; then compound 2.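

In this assay taking the methylsulfinyl group off gives a 34-fold higher number from compound 3 to compound 4 (1.53 log units; beyond the scatter) and so shows that this group, rather than the shared core alone, carries much of the low number of compound 3. Hydrogen in place of dimethylcarbamoyl at the same place gives only a 2.1-fold higher number from compound 1 to compound 4 (0.32 log units; beyond the scatter) and so shows that both groups give lower numbers than hydrogen, but by very different margins. On the triple-bonded carbon, phenyl in place of pyridin-4-yl gives a 5.6-fold lower number from compound 2 to compound 4 (0.75 log units; beyond the scatter) and so shows that the choice of ring there also moves the number.

As far as these compounds go, only these two groups can be set against hydrogen at this place, so how an amine, a methylsulfonyl group or a longer chain would compare remains open. Nothing shown explains why the methylsulfinyl and dimethylcarbamoyl groups differ so much.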